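The source may hold more compounds than are shown below. What is called first, only, known or untested is meant among the compounds shown, and "the series" means these compounds.

Measured compounds:
compound 1 `Cc1cnc(Nc2ccc(C(=O)Nc3c(C)cccc3C)cc2)nc1-c1cccc(OC(F)(F)F)c1` gives 1.2 nM
compound 2 `Cc1cnc(Nc2ccc(C(=O)Nc3c(C)cccc3C)cc2)nc1-c1ccc(C#N)cc1` gives 2.8 nM
compound 3 `Cc1cnc(Nc2ccc(C(=O)Nc3c(C)cccc3C)cc2)nc1-c1ccc(F)cc1` gives 2.2 nM

All three share one core and differ only in the aryl group attached to it, and all three were measured in an assay on NIH3T3 cells for inhibition of Sonic hedgehog protein (Mus musculus), read by a luciferase reporter, with a stated time of 48 h; on this read-out higher numbers stand for weaker inhibition and lower numbers for stronger inhibition. Compound 3 lies within the usual scatter of both compound 1 and compound 2, so the three numbers cannot be ordered with confidence. The steps among them are small: a 2.3-fold higher number from compound 1 to compound 2 (0.37 log units; beyond the scatter), a 1.8-fold higher number from compound 1 to compound 3 (0.26 log units; within the scatter) and a 1.3-fold lower number from compound 2 to compound 3 (0.10 log units; within the scatter).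

Compound 4 `Cc1cnc(Nc2ccc(C(=O)Nc3c(C)cccc3C)cc2)nc1-c1ccncc1` carries the change (pyridin-4-yl in place of 4-fluorophenyl on an aromatic carbon). Among the measured compounds shown here, no measured step exchanges this ring for a pyridine, so none bears directly on it; the nearest guide is that exchanging one substituted phenyl for another on this position moved the number only modestly at most. The expectation is therefore a step of a 1.6-fold higher number from compound 3 to compound 4 (0.20 log units; within the scatter), not beyond the scatter. Compound 4 is estimated to give 3.5 nM in this assay, with a range from 1.2 nM to 12 nM.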

Compound 4, half-maximal inhibitory concentration: 0.54 nM
Estimate against measurement, compound 4: 6.5-fold (0.81 log units) above, and the stated range ends above it.
By their numbers in this assay, from the lowest: compound 4; then compounds 1, 3 and 2 (each within the scatter of the next, the first and the last beyond it).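

In this assay, pyridin-4-yl sets compound 4 apart from all three phenyl-bearing compounds, with a 4.1-fold lower number from compound 3 to compound 4 (0.61 log units; beyond the scatter) and a 5.2-fold lower number from compound 2 to compound 4 (0.71 log units; beyond the scatter) and also a 2.2-fold lower number from compound 1 to compound 4 (0.35 log units; beyond the scatter) on this read-out. Among the compounds shown here, the earlier compounds showed only that three substituted phenyl rings at this position stay close together, whereas this result shows that a six-membered aromatic ring with a hetero atom can give a clearly lower number, making compound 4 the most potent of the four. Nothing shown accounts for the drop.

The compounds leave open whether the gain belongs to the ring nitrogen or to the absence of a phenyl substituent, which unsubstituted phenyl would help separate. They also leave open whether the nitrogen's place in the ring matters, as pyridin-3-yl or pyridin-2-yl would show.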